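This account rests on a few compounds, and the source may have more. Where it says the series, first, only, none or still open, it means among the compounds named here.

Measured compounds:
- compound 1, `O=C(COc1ccc(F)cc1)N1CCc2cc(S(=O)(=O)Nc3nccs3)ccc21`: 2510 nM
- compound 2, `O=S(=O)(Nc1nccs1)c1ccc(-c2nnc(Cc3ccc(Cl)c(Cl)c3)[nH]2)cc1`: 45 nM
- compound 3, `O=C(NCc1ccc(OC(F)(F)F)c(Cl)c1)c1ccc(S(=O)(=O)Nc2ncns2)c(F)c1`: 13 nM

In an assay on cells for inhibition of sodium channel protein type 3 subunit alpha (Homo sapiens), read by electrophysiology (on this read-out lower numbers stand for stronger inhibition and higher numbers for weaker inhibition), compound 3 gives 13 nM, the lowest of the three numbers. Compound 2 gives 45 nM and lies beyond the scatter from compound 3, while compound 1 gives 2510 nM and stands far from both. Compound 3 is therefore the strongest inhibitor among the three measured compounds.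

Compound 4, `O=C(NCc1ccc(OC(F)(F)F)c(Cl)c1)c1ccc(S(=O)(=O)Nc2cncnc2)c(F)c1`, has not yet been measured. It differs from compound 3 in one place: pyrimidin-5-yl in place of 1,2,4-thiadiazol-5-yl on a sulfonamide nitrogen. Among the compounds with values here, no pair of measured compounds shows this change, so the step has to be guessed from the structure alone. Within the data shown here, the three measured compounds all carry a five-membered heteroaryl on the sulfonamide nitrogen, and compound 4 is the first with a six-membered one there. The author expects a weakening step beyond the scatter, a 31-fold higher number from compound 3 to compound 4 (1.49 log units; beyond the scatter). Compound 4 is estimated at 400 nM in this assay, with a range from 60 nM to 3000 nM.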

Compound 4, half-maximal inhibitory concentration in the sodium channel protein type 3 subunit alpha assay: > 3000 nM
Compound 4 was reported as a limit; the forecaster's own chance of this, stated with the estimate: 15%; middle value at least 7.5-fold (0.87 log units) from the limit.
By their numbers in the sodium channel protein type 3 subunit alpha assay, from the lowest: compound 3; then compound 2; then compound 1. At a limit, above all of these: compound 4.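

Within the data shown here, putting pyrimidin-5-yl in place of 1,2,4-thiadiazol-5-yl on a sulfonamide nitrogen gives the first single-place step at this position in the sodium channel protein type 3 subunit alpha assay, an at least 230-fold higher number from compound 3 to compound 4 (2.36 log units; beyond the scatter), so the group held there matters greatly. In the sodium channel protein type 3 subunit alpha assay compound 4 gives > 3000 nM, which is a limit of the assay and not a number. In a physicochemical assay for acid dissociation, compound 3 gives 3.3 and compound 4 gives 4.6. In the physicochemical assay the same change leaves the proton given up less readily, a shift that accompanies the higher read-out in the sodium channel protein type 3 subunit alpha assay but is not shown to cause it: the measured acid dissociation constant of compound 3, 3.3, and of compound 4, 4.6, a number 1.30 log units higher (beyond the scatter)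

This one pair changes the acid dissociation constant and the ring together, so the compounds shown cannot separate the two. They also leave open how a pyridin-2-yl or a 1,3,4-thiadiazol-2-yl on the same sulfonamide nitrogen would behave.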